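The source may report more compounds than this note shows. Statements on the series, on what has been measured and on what is new or still open speak of the compounds shown alone.

Measured compounds:
- compound 1, `CC[C@H](C)[C@H](NC(=O)CN(c1nc(Cl)nc2[nH]cnc12)C1CC1)C(=O)O`, 6.71%
- compound 2, `C[C@@H](O)[C@H](NC(=O)CN(c1nc(Cl)nc2[nH]cnc12)C1CC1)C(=O)OCc1ccccc1`, 12.8%
- compound 3, `NC(=O)C[C@H](NC(=O)CN(c1nc(Cl)nc2[nH]cnc12)C1CC1)C(=O)O`, 7.51%

In a functional assay on the whole organism (Tail, strain ICR) with Mus musculus as the target, in the tail flick test, with a stated time of 150 min, at a dose of 25 umol/kg by the oral route (a lower number here means a weaker effect, a higher number a stronger effect of the compound at the dose given), compound 3 gives 7.51%. Its value lies within the scatter of both compound 1 and compound 2, so the three measured compounds cannot be told apart on these numbers.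

Compound 4, `O=C(O)CC[C@H](NC(=O)CN(c1nc(Cl)nc2[nH]cnc12)C1CC1)C(=O)O`, is the next one to be measured. The change from compound 3 is carboxymethyl in place of carbamoyl on a saturated chain carbon, two bonds along the chain from an amide-type nitrogen and a carbonyl carbon. Going by the values given here, the only measured step at the same chain carbon is a number 0.8 percentage points higher from compound 1 to compound 3 (within the scatter), a change that stayed within the scatter. Among the compounds with values here, no step at this carbon has moved the read-out beyond the scatter, so no step beyond the scatter is expected here either; the estimated step is a number 0 percentage points lower from compound 3 to compound 4 (within the scatter). Compound 4 is therefore expected to give about 7.5%, in the range 2% to 14%.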

Compound 4, a percentage reported as activity, at one dose (the size of the read-out at that dose, not a potency): 29.5%
Compound 4: the middle estimate sits 22 percentage points below what was measured; measured number above the stated range.
By their numbers in this assay, from the lowest: compounds 1, 3 and 2 (each within the scatter of the next); then compound 4.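

In this assay this chain carbon is no longer silent: carboxymethyl in place of carbamoyl gives a number 22 percentage points higher from compound 3 to compound 4 (beyond the scatter) and 2-carboxyethyl in place of sec-butyl gives a number 22.8 percentage points higher from compound 1 to compound 4 (beyond the scatter) as well. Both steps end at compound 4, so among the groups shown at this carbon only 2-carboxyethyl stands apart, while carbamoylmethyl and sec-butyl remain within the scatter of each other.

Going by these compounds, whether an amine on this chain, or a longer chain ending in a carboxylic acid, would keep this gain remains open. No measurement at hand accounts for the rise.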